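Chloro for Amino: Expecting the Cytotoxicity of Compound 4

The source may hold more compounds than are shown below. What is called first, only, known or untested is meant among the compounds shown, and "the series" means these compounds.

Measured compounds:
Compound 1, `Nc1nc(Cl)c2ncn(Cc3ccccc3CCl)c2n1`: 75900 nM
Compound 2, `Nc1nc(Cl)c2ncn(Cc3ccc(CCl)cc3)c2n1`: 64600 nM
Compound 3, `ClCc1ccc(Cn2cnc3c(Cl)nc(Cl)nc32)cc1`: 14800 nM

In a functional assay on ACHN cells (Homo sapiens) for cytotoxicity, read by sulforhodamine B assay, with a stated time of 48 h (a lower number here means that less compound is tolerated, a higher number that more compound is tolerated), compound 1 stands highest of the three numbers, meaning the most compound is tolerated by the cells. Compound 2 lies within the usual scatter of compound 1, so the two cannot be told apart. Compound 3 gives a clearly lower number than compound 1, beyond the scatter.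

Compound 4, `ClCc1ccccc1Cn1cnc2c(Cl)nc(Cl)nc21`, differs from compound 1 in one place: chloro in place of amino on an aromatic carbon. The same exchange has already been measured once, on compound 2, which shares the core but carries its side chain at another position; there it gave a 4.4-fold lower number from compound 2 to compound 3 (0.64 log units; beyond the scatter). Within the data shown here, that single step is the only guide here, and it suggests that the chloro compound is tolerated less well than its amino counterpart.

A comparable, modest drop is therefore expected for compound 4 in this assay, a step of a 4.5-fold lower number from compound 1 to compound 4 (0.65 log units; beyond the scatter). The value of compound 4 is estimated at 17000 nM, with a range of 7000 nM to 40000 nM.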

Compound 4, concentration lethal to 50% of the cells: 4160 nM
For compound 4 the middle estimate is 4.1-fold (0.61 log units) above the measured one, outside the stated range (below it).
By their numbers in this assay, from the lowest: compound 4; then compound 3; then compounds 2 and 1 (each within the scatter of the next).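

In this assay, chloro in place of amino on this aromatic carbon, between two ring nitrogen atoms, gives an 18-fold lower number from compound 1 to compound 4 (1.26 log units; beyond the scatter), so the direction seen on the earlier pair also appears on a second core. The size of the step, however, does not carry over from one core to the other: the same change on two cores in this assay, a 4.4-fold lower number (0.64 log units; beyond the scatter) from compound 2 to compound 3 and an 18-fold lower number (1.26 log units; beyond the scatter) from compound 1 to compound 4, 4.2-fold (0.62 log units) apart, beyond the scatter of two such steps. A single step on one core is therefore a poor guide to the size of the same change on a closely related core, even when it points the right way.

Going by these compounds, what a methoxy group or a dimethylamino group would do on this carbon remains open. Also open, on these data alone, is whether the gap between the two steps would persist with a methyl group in place of the chloromethyl group on the side chain.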